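Dropping One Chlorine from a Trichlorophenyl Urea

A few compounds are considered here, and "the series" means these few. Any claim that something is new, unique, unknown or untested is made for them only; others in the source may bear on it.

Compound 1 `COc1cc(Nc2ncnc3c(NC(=O)Nc4cc(Cl)c(Cl)cc4Cl)cccc23)cc(OC)c1` carries a 2,4,5-trichlorophenyl urea on the shared core. In a functional assay on RT-112 cells (Homo sapiens) for antiproliferative activity, read by MTT assay, with a stated time of 72 h (on this read-out higher numbers stand for weaker inhibition of growth and lower numbers for stronger inhibition of growth), compound 1 gives 4890 nM, the highest of the two numbers measured here and a weaker inhibitor than compound 2 `COc1cc(Nc2ncnc3c(NC(=O)Nc4cc(C(F)(F)F)cc(C(F)(F)F)c4)cccc23)cc(OC)c1`, which in this assay gives 467 nM. Compound 3 `COc1cc(Nc2ncnc3c(NC(=O)Nc4ccc(Cl)c(Cl)c4)cccc23)cc(OC)c1` differs from compound 1 by a single change: hydrogen in place of chloro on an aromatic carbon. Within the data shown here, no measured pair shows this same change, so its size is open. Compound 3 is expected to gain modestly, with a 2.0-fold lower number from compound 1 to compound 3 (0.29 log units; within the scatter). Compound 3 is estimated at 2500 nM, between 800 nM and 8000 nM.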

Compound 3, concentration for 50% growth inhibition: 6230 nM
Beside the measured number, compound 3's estimate is 2.5-fold (0.40 log units) below it, within the range that was stated.
By their numbers in this assay, from the lowest: compound 2; then compounds 1 and 3 (each within the scatter of the next).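

In this assay, putting hydrogen in place of chloro on this aromatic carbon, ortho to a large group, gives a 1.3-fold higher number from compound 1 to compound 3 (0.11 log units; within the scatter). Among these compounds, this is the first reading of the change, and it shows that removing this chloro group leaves no difference in growth inhibition that can be told from ordinary repeat variation. Nothing available here accounts for this result.

Going by these compounds, whether a methoxy group, an amine or a carboxylic acid on this carbon would shift the number remains open. So does the effect of removing either of the two remaining chloro groups.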